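The compounds below may be only part of what the source reports. "The series", "measured", "known", "first", "only" and "open" are said of these compounds alone.

Measured compounds:
Compound 1, `COc1cc(Cn2cc(CNC(=O)c3ccc([N+](=O)[O-])o3)nn2)ccc1F`, gives 225000 nM in an ADME assay on Vero cells (Chlorocebus sabaeus) for cytotoxicity; on this read-out lower numbers stand for stronger inhibition and higher numbers for weaker inhibition.
Compound 2, `O=C(NCc1cn(Cc2ccc(F)c(Cl)c2)nn1)c1ccc([N+](=O)[O-])o1`, gives 344000 nM in this assay.

Among the measured compounds shown here, of these two numbers, compound 2 holds the higher one, though the single measured step, a 1.5-fold higher number from compound 1 to compound 2 (0.18 log units; within the scatter), is within the scatter, so the two compounds cannot be told apart on this read-out. Compound 3, `O=C(NCc1cn(Cc2cccc([N+](=O)[O-])c2)nn1)c1ccc([N+](=O)[O-])o1`, has not yet been measured. It differs from compound 2 in one place: 3-nitrophenyl in place of 3-chloro-4-fluorophenyl on a saturated chain carbon bound to an aromatic nitrogen. For the measured compounds named here, no measured step involves a nitrophenyl group on this chain carbon, so the only guidance comes from the step from compound 1 to compound 2, which exchanged one substituent on the same aromatic ring and stayed within the scatter. The change to compound 3 is larger, replacing the whole ring with its substituents, and nothing measured bears on it directly. On that basis the expectation for compound 3 in this assay is a step of a 1.1-fold lower number from compound 2 to compound 3 (0.06 log units; within the scatter), meaning no movement beyond the scatter, with a wide range to reflect the lack of direct evidence. The estimated value for compound 3 is 300000 nM, spanning from 100000 nM to 900000 nM.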

Compound 3, half-maximal inhibitory concentration: 326000 nM
Beside the measured number, compound 3's estimate is 1.1-fold (0.04 log units) below it, within the range that was stated.
By their numbers in this assay, from the lowest: compounds 1, 3 and 2 (each within the scatter of the next).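

In this assay, 3-nitrophenyl in place of 3-chloro-4-fluorophenyl on this saturated chain carbon gives a 1.1-fold lower number from compound 2 to compound 3 (0.02 log units; within the scatter), and 3-nitrophenyl in place of 4-fluoro-3-methoxyphenyl gives a 1.4-fold higher number from compound 1 to compound 3 (0.16 log units; within the scatter). The earlier pair showed only one substituent exchanged on the aromatic ring, whereas these steps replace the whole substituted phenyl group with one that carries a nitro group and no halogen, and still the three compounds cannot be told apart on this read-out. Nothing available explains why these changes leave the read-out within the scatter.

As far as these compounds go, all three compounds carry a substituted phenyl ring on this chain carbon, so it remains open whether the read-out would stay within the scatter with a different kind of group there, such as an amine, a carboxylic acid or a longer chain. They also share one core, which leaves open whether a change to the core itself would separate compounds in this assay in a way these ring exchanges do not.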